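Substituent Changes on an Aromatic Nitrogen and Microsomal Half-Life

The source may report more compounds than this note shows. Statements on the series, on what has been measured and on what is new or still open speak of the compounds shown alone.

Three compounds sharing one core were measured in an ADME assay (liver, Mus musculus) for metabolic stability, using microsomes; a lower number here means that the compound disappears faster, a higher number that the compound lasts longer. Compound 1 `C=CC(=O)Nc1cccc(CNc2nc(Nc3cn(C)nc3C)ncc2Cl)c1` gives 0.138 h. Compound 2 `C=CC(=O)Nc1cccc(CNc2nc(Nc3cnn(C(F)F)c3)ncc2Cl)c1` gives 0.173 h, and compound 3 `C=CC(=O)Nc1cccc(CNc2nc(Nc3cnn(CC(=O)N4CCOCC4)c3)ncc2Cl)c1` gives 0.12 h. Both steps among them, a 1.3-fold higher number from compound 1 to compound 2 (0.10 log units; within the scatter) and a 1.4-fold lower number from compound 2 to compound 3 (0.16 log units; within the scatter), stay within the scatter, so compound 3 cannot be told apart from either of the others on these numbers. Compound 4 `C=CC(=O)Nc1cccc(CNc2nc(Nc3cnn(CCOC(F)F)c3)ncc2Cl)c1` is not yet measured; it differs from compound 3 by (difluoromethoxy)methyl in place of (morpholin-4-yl)carbonyl on a saturated chain carbon bound to an aromatic nitrogen, the same change read one bond further out being ((morpholin-4-yl)carbonyl)methyl to 2-(difluoromethoxy)ethyl. The two known steps at this nitrogen-bound position moved nothing beyond the scatter, so for compound 4 the expected step of a 1.2-fold higher number from compound 3 to compound 4 (0.07 log units; within the scatter) is likewise taken to be no more than scatter. The estimate for compound 4 in this assay is 0.14 h, with a range from 0.07 h to 0.28 h.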

Compound 4, half-life: 0.0433 h
Compound 4: the middle estimate sits 3.2-fold (0.51 log units) above what was measured, outside the stated range (below it).
By their numbers in this assay, from the lowest: compound 4; then compounds 3, 1 and 2 (each within the scatter of the next).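

Within the data shown here, at this position on an aromatic nitrogen, the substituent now matters in this assay: exchanging (morpholin-4-yl)carbonyl for (difluoromethoxy)methyl gives the first step beyond the scatter (a 2.8-fold lower number from compound 3 to compound 4 (0.44 log units; beyond the scatter)), and 2-(difluoromethoxy)ethyl in place of difluoromethyl gives another (a 4.0-fold lower number from compound 2 to compound 4 (0.60 log units; beyond the scatter)). Among these compounds, compound 4 thus stands apart from compound 2 and compound 3, which the earlier steps could not separate. No evidence shown accounts for this drop. From the compounds shown here alone, it remains open whether a 2-methoxyethyl group, an amine or a carboxylic acid on this chain would give a similar number, and whether a longer chain would.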